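The source may report more compounds than this note shows. Statements on the series, on what has been measured and on what is new or still open speak of the compounds shown alone.

Compound 1 `CCCCCN1C(=O)C/C(=C\c2cccc(C(=O)Nc3cccc(CC)c3)c2)C1=O` was tested first. In an ADME assay on NCM460 cells (Homo sapiens) for cytotoxicity, read by MTT assay, with a stated time of 72 h (a lower number here means a stronger inhibitor, a higher number a weaker inhibitor), compound 1 gives only the limit > 100000 nM.
Compound 2 `CCCCCN1C(=O)C/C(=C\c2cccc(C(=O)NCCCC)c2)C1=O` was tested too. In this assay compound 2 gives only the limit > 100000 nM.
Compound 3 `CCCCCN1C(=O)C/C(=C\c2cccc(C(=O)Nc3ccc(OC)cc3)c2)C1=O` was tested as well. In this assay compound 3 gives only the limit > 100000 nM.

Compound 2 therefore stands where every measured compound stands: at the limit of > 100000 nM in this assay, at which 3 of the 3 values shown sit. The steps a step that the two limits leave unreadable from compound 1 to compound 2, a step that the two limits leave unreadable from compound 1 to compound 3 and a step that the two limits leave unreadable from compound 2 to compound 3 are all hidden by that limit, so no size can be read for any of them. Compound 4 `CCCCNC(=O)c1cccc(/C=C2\CC(=O)N(Cc3ccccc3)C2=O)c1` is built from compound 2 by the change (phenyl in place of butyl on a saturated chain carbon bound to an amide-type nitrogen in a ring). Within the data shown here, none of the measured steps touches that place; they all concern the amide-type nitrogen on the other side of the shared core, and even there nothing readable emerged. Among the measured compounds shown here, the only guidance is that every variation tried so far left this assay at its limit. Compound 4 is thus expected to give no readable step, a step that the limit leaves unreadable from compound 2 to compound 4, and its value in this assay is estimated at 150000 nM, within 50000 nM to 500000 nM.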

Compound 4, half-maximal inhibitory concentration: > 100000 nM
Compound 4: no number, only a limit (the forecaster's own chance of this, stated with the estimate: 85%); the middle value lies beyond the limit too.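

Among these compounds, compound 2 and compound 4 both give only a limit, so no step between them can be read. The compounds shown leave open how far any of the four values lies beyond that limit, and whether any change on either amide-type nitrogen would give a readable value.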